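4-Fluorophenyl to 4-cyanophenyl: expected antiproliferative step

A few compounds are considered here, and "the series" means these few. Any claim that something is new, unique, unknown or untested is made for them only; others in the source may bear on it.

Within the data shown here, in a functional assay on A549 cells (Homo sapiens) for antiproliferative activity, read by MTT assay, with a stated time of 72 h (on this read-out lower numbers stand for stronger inhibition and higher numbers for weaker inhibition), compound 2 (`O=C(N/N=C/c1ccc(F)cc1)Nc1ccc(Oc2ccnc3[nH]ccc23)c(F)c1`) gives 680 nM, the lower of the two numbers so far, while compound 1 (`O=C(N/N=C/c1ccccc1)Nc1ccc(Oc2ccnc3[nH]ccc23)c(F)c1`) gives 2500 nM. Compound 3 (`N#Cc1ccc(/C=N/NC(=O)Nc2ccc(Oc3ccnc4[nH]ccc34)c(F)c2)cc1`) carries cyano in place of fluoro on an aromatic carbon, para to a large group: cyano in place of fluoro on an aromatic carbon. Among the measured compounds shown here, the only measured step bearing on this is the modest 3.7-fold lower number from compound 1 to compound 2 (0.57 log units; beyond the scatter), with fluoro in place of hydrogen. It offers no measured case of cyano, so no shift beyond the scatter is expected in this assay. The expected change is a 1.1-fold lower number from compound 2 to compound 3 (0.05 log units; within the scatter). For compound 3 the estimated value is 600 nM, with an expected range of 220 nM to 1700 nM.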

Compound 3, half-maximal inhibitory concentration: 1360 nM
Beside the measured number, compound 3's estimate is 2.3-fold (0.36 log units) below it; low and high end bracket the measured number.
By their numbers in this assay, from the lowest: compounds 2, 3 and 1 (each within the scatter of the next, the first and the last beyond it).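

In this assay cyano in place of fluoro on this aromatic carbon, para to a large group, gives a 2.0-fold higher number from compound 2 to compound 3 (0.30 log units; within the scatter) and cyano in place of hydrogen gives a 1.8-fold lower number from compound 1 to compound 3 (0.26 log units; within the scatter) at the same carbon. The position therefore takes cyano with no shift beyond the scatter against either fluoro or hydrogen, whereas the earlier pair showed only fluoro separating from hydrogen. No measurement shown here accounts for these steps.

On these data alone, whether an amine, a methoxy group or a carboxylic acid on this carbon would move the number beyond the scatter stays open. As far as these compounds go, whether these steps hold in other cell lines also stays open.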